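This account rests on a few compounds, and the source may have more. Where it says the series, first, only, none or still open, it means among the compounds named here.

The measured compounds:
Compound 3, `NCCCCOc1ccc2c(=O)c(-c3ccc(O)cc3)coc2c1`, gives 250 nM in an assay (Cricetulus griseus) for inhibition of aldehyde dehydrogenase, mitochondrial (Homo sapiens); on this read-out higher numbers stand for weaker inhibition and lower numbers for stronger inhibition.
Compound 1, `O=c1c(-c2ccc(O)cc2)coc2cc(OCCCCCCCCCO)ccc12`, gives 700 nM in this assay.
Compound 2, `O=c1c(-c2ccc(O)cc2)coc2cc(OCCCCCCCCCCCCO)ccc12`, gives 1700 nM in this assay.

Compound 3 stands lowest of the three, with a 2.8-fold lower number from compound 1 to compound 3 (0.45 log units; beyond the scatter) and a 6.8-fold lower number from compound 2 to compound 3 (0.83 log units; beyond the scatter) both beyond the scatter. Compound 4, `O=C(O)CCCCCCOc1ccc2c(=O)c(-c3ccc(O)cc3)coc2c1`, differs from it by 2-carboxyethyl in place of amino on a saturated chain carbon, four bonds along the chain from an oxygen on an aromatic ring. Among the measured compounds shown here, the steps that bear on this run the other way: both replacements of a hydroxyl-ending chain by amino lowered the number, and chain lengthening raised it, as a 2.4-fold higher number from compound 1 to compound 2 (0.39 log units; beyond the scatter) shows. Replacing amino with a longer chain is therefore expected to raise the number modestly, about a 2.4-fold higher number from compound 3 to compound 4 (0.38 log units; beyond the scatter). Compound 4 is estimated at 600 nM, in the range 250 nM to 1500 nM.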

Compound 4, half-maximal inhibitory concentration: 50 nM
Compound 4: the middle estimate sits 12-fold (1.08 log units) above what was measured, outside the stated range (below it).
By their numbers in this assay, from the lowest: compound 4; then compound 3; then compound 1; then compound 2.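

Among the compounds shown, the carboxylic acid end gives the lowest number: 2-carboxyethyl in place of amino brings a 5.0-fold lower number from compound 3 to compound 4 (0.70 log units; beyond the scatter) and so adds chain without the rise seen in a 2.4-fold higher number from compound 1 to compound 2 (0.39 log units; beyond the scatter) among the hydroxyl-ending chains. Against those chains the change is large, with a 14-fold lower number from compound 1 to compound 4 (1.15 log units; beyond the scatter) and a 34-fold lower number from compound 2 to compound 4 (1.53 log units; beyond the scatter) on the same core. Nothing available here accounts for this.

The compounds shown leave the acid and the chain length unseparated. An amine on a chain as long as that of compound 4, or a carboxylic acid on a shorter chain, would separate them.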